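From vinyl to 2-phenylethenyl on compound 2

A few compounds are considered here, and "the series" means these few. Any claim that something is new, unique, unknown or untested is made for them only; others in the source may bear on it.

In a functional assay on HCT-116 cells (Homo sapiens) for inhibition (on this read-out lower numbers stand for stronger inhibition and higher numbers for weaker inhibition), so far
- compound 1 `COc1ccc2oc(=O)cc(COC(=O)C=C(C)C)c2c1` gives > 10 ug/mL (a limit)
- compound 2 `C=CC(=O)OCc1cc(=O)oc2cc(OC)c(OC)cc12` gives > 10 ug/mL (a limit)

Compound 2 stands at > 10 ug/mL as a limit of the assay and not a number. Among the measured compounds shown here, the series so far offers only the limit of > 10 ug/mL in this assay, at which 2 of the 2 values shown sit, and no measured step to scale from. Compound 3 `COc1cc2oc(=O)cc(COC(=O)/C=C/c3ccccc3)c2cc1OC` is the next to be read. It carries 2-phenylethenyl in place of vinyl on a carbonyl carbon and otherwise matches compound 2. In this assay only a small move toward stronger inhibition is expected, and a further reading at the limit stays likely. The step expected is a step that the limit leaves unreadable from compound 2 to compound 3 and is no more than a loose estimate. For compound 3 the estimate is 12 ug/mL (expected range 5 ug/mL to 30 ug/mL).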

Compound 3, half-maximal inhibitory concentration: > 10 ug/mL
Compound 3 ended at the assay's limit; the forecaster's own chance of this, stated with the estimate: 65%; the middle value lies beyond the limit too.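

No step can be read from compound 2 to compound 3 in this assay, since both stand at a limit of the assay and not at a number: the limit of > 10 ug/mL in this assay, at which 3 of the 3 values shown sit. From the compounds shown here alone, whether 2-phenylethenyl in place of vinyl on a carbonyl carbon alters inhibition at all stays open.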